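The compounds below may be only part of what the source reports. "The series", "measured", "known", "first", "only" and "open" are said of these compounds alone.

In a physicochemical assay for solubility, using the shake flask method, in simulated intestinal fluid, measured as kinetic solubility, with a stated time of 2 h, at 25 degrees C, at pH 6.5 (on this read-out lower numbers stand for lower solubility and higher numbers for higher solubility), compound 1 (`Cc1noc(-c2nc(C)c3c(c2N)C(=O)N(Cc2ccc(Oc4ccc(F)cc4)cc2)C3=O)n1`) gives 23800 nM. Compound 2 (`COc1ccc(CN2C(=O)c3c(C)nc(-c4nc(C)no4)c(N)c3C2=O)cc1`) gives only a limit, < 5000 nM, and so has no exact place on the scale. Going by the values given here, the one measured step is an at least 4.7-fold lower number from compound 1 to compound 2 (0.67 log units; beyond the scatter), with methyl in place of 4-fluorophenyl on an oxygen on an aromatic ring.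

Compound 3 (`Cc1noc(-c2nc(C)c3c(c2N)C(=O)N(C(C)c2ccccc2)C3=O)n1`) now carries 1-phenylethyl in place of 4-methoxybenzyl on an amide-type nitrogen in a ring. Among the compounds with values here, the measured step touched the same group on that nitrogen, so it is the only guide available, but it bears on the new change only indirectly. It exchanged a whole 4-fluorophenyl for methyl, a larger exchange than the one from 4-methoxybenzyl to 1-phenylethyl, and a step of that size is therefore not expected here. No step beyond the scatter is expected in this assay, in either direction, and another limit is a real possibility. For compound 3 the expected value is 5000 nM, with an estimated range from 2500 nM to 14000 nM. The expected step is a number no lower from compound 2 to compound 3 (the limit leaves the size open).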

Compound 3, solubility: 10900 nM
The estimate for compound 3 lay 2.2-fold (0.34 log units) below the measured number; measured number inside the range.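

In this assay, 1-phenylethyl in place of 4-methoxybenzyl on an amide-type nitrogen in a ring brings an at least 2.1-fold higher number from compound 2 to compound 3 (0.33 log units; beyond the scatter). Going by these compounds alone, compound 3 gives 10900 nM, an exact number, so the group on this nitrogen now has a second exact value besides the one for compound 1. Compound 2 gives only a limit, so the true size of this step remains unknown: the limit of < 5000 nM in this assay, at which 1 of the 3 values shown sits.

The change replaces one whole group with another, so the compounds shown do not separate the loss of the methoxy oxygen from the change from a benzyl to a 1-phenylethyl arrangement, a question that a plain benzyl on the same nitrogen would address. They also leave open how this read-out responds to a group of another kind at this place, such as an amine or a carboxylic acid carried on the phenyl ring, and whether the change would give a step of similar size on a different core.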